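From hydroxymethyl to dimethylamino on the chain of compound 3

The source may hold more compounds than are shown below. What is called first, only, known or untested is meant among the compounds shown, and "the series" means these compounds.

Measured values in a functional assay on CCRF-CEM cells (Homo sapiens) (on this read-out higher numbers stand for lower toxicity in this test and lower numbers for higher toxicity in this test), are these:
- compound 1 `Cc1cn([C@@H]2O[C@H](CO[Si](C)(C)C(C)(C)C)[C@@]3(OS(=O)(=O)C=C3N)[C@H]2O[Si](C)(C)C(C)(C)C)c(=O)n(CC(N)=O)c1=O` gives 13300 nM
- compound 2 `Cc1cn([C@@H]2O[C@H](CO[Si](C)(C)C(C)(C)C)[C@@]3(OS(=O)(=O)C=C3N)[C@H]2O[Si](C)(C)C(C)(C)C)c(=O)n(Cc2ccccc2)c1=O` gives 53000 nM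
- compound 3 `Cc1cn([C@@H]2O[C@H](CO[Si](C)(C)C(C)(C)C)[C@@]3(OS(=O)(=O)C=C3N)[C@H]2O[Si](C)(C)C(C)(C)C)c(=O)n(CCCCO)c1=O` gives 20500 nM

Compound 3 lies within the scatter of compound 1 and has a lower number than compound 2. Compound 4 `Cc1cn([C@@H]2O[C@H](CO[Si](C)(C)C(C)(C)C)[C@@]3(OS(=O)(=O)C=C3N)[C@H]2O[Si](C)(C)C(C)(C)C)c(=O)n(CCCN(C)C)c1=O` carries dimethylamino in place of hydroxymethyl on a saturated chain carbon, three bonds along the chain from an aromatic nitrogen. The closest evidence is small: a 1.5-fold higher number from compound 1 to compound 3 (0.19 log units; within the scatter) stays within the scatter. The modest steps of a 4.0-fold higher number from compound 1 to compound 2 (0.60 log units; beyond the scatter) and a 2.6-fold lower number from compound 2 to compound 3 (0.41 log units; beyond the scatter) both involve compound 2. Among the measured compounds shown here, no measured compound carries dimethylamino, so the expectation in this assay is cautious. The estimated 1.2-fold lower number from compound 3 to compound 4 (0.08 log units; within the scatter) is expected to stay within the scatter. Compound 4 is expected at 17000 nM in a range from 6000 nM to 45000 nM in this estimate.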

Compound 4, half-maximal cytotoxic concentration: 10400 nM
The estimate for compound 4 lay 1.6-fold (0.21 log units) above the measured number; the measured number falls inside the stated range.
By their numbers in this assay, from the lowest: compounds 4, 1 and 3 (each within the scatter of the next); then compound 2.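

In this assay, dimethylamino in place of hydroxymethyl, on a saturated chain carbon three bonds along the chain from an aromatic nitrogen, gives a 2.0-fold lower number from compound 3 to compound 4 (0.29 log units; within the scatter), so this change leaves the number within the scatter. The step of a 1.3-fold lower number from compound 1 to compound 4 (0.11 log units; within the scatter) also stays within the scatter, while a 5.1-fold lower number from compound 2 to compound 4 (0.71 log units; beyond the scatter) lies beyond it, so among these four compounds only compound 2, with its phenyl, stands apart. Nothing measured here accounts for these numbers. From the compounds shown here alone, whether a carboxylic acid, a morpholine or a longer chain ending in dimethylamino would stay within the scatter of compound 4 remains open.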